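Methoxy for fluoro on the shared core

The source may hold more compounds than are shown below. What is called first, only, known or untested is meant among the compounds shown, and "the series" means these compounds.

Three compounds with the shared core have numbers in a functional assay on DLD-1 cells (Homo sapiens) for cytotoxicity, with a stated time of 48 h; on this read-out higher numbers stand for weaker inhibition and lower numbers for stronger inhibition. Compound 1 `CC(C)C(=O)Oc1ccc2oc(/C=C/[S+](C)[O-])cc(=O)c2c1` gives 9100 nM, compound 2 `CC(C)COc1ccc2oc(/C=C/[S+](C)[O-])cc(=O)c2c1` gives 5000 nM, and compound 3 `C[S+]([O-])/C=C/c1cc(=O)c2cc(F)ccc2o1` gives 7000 nM. Compound 3 stands second highest of the three: its number is nearest that of compound 1, a 1.3-fold lower number from compound 1 to compound 3 (0.11 log units; within the scatter), and furthest from that of compound 2, a 1.4-fold higher number from compound 2 to compound 3 (0.15 log units; within the scatter). Every step among the three, including a 1.8-fold lower number from compound 1 to compound 2 (0.26 log units; within the scatter), lies within the scatter, so no order can be read among them.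

Compound 4 `COc1ccc2oc(/C=C/[S+](C)[O-])cc(=O)c2c1` differs from compound 3 thus: methoxy in place of fluoro on an aromatic carbon. The step that bears on it most is a 1.4-fold higher number from compound 2 to compound 3 (0.15 log units; within the scatter), where isobutoxy gave way to fluoro on the same aromatic carbon and the number hardly moved; a 1.3-fold lower number from compound 1 to compound 3 (0.11 log units; within the scatter) says the same of (isopropylcarbonyl)oxy. Putting methoxy in place of fluoro is therefore expected to shift the number in this assay by no more than the scatter, with no direction favoured.

Compound 4 is expected to give 6000 nM in this assay, within 3000 nM to 12000 nM. The estimated step is a 1.2-fold lower number from compound 3 to compound 4 (0.07 log units; within the scatter).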

Compound 4, half-maximal inhibitory concentration: 5700 nM
For compound 4 the middle estimate is 1.1-fold (0.02 log units) above the measured one, and the stated range covers the measured number.
By their numbers in this assay, from the lowest: compounds 2, 4, 3 and 1 (each within the scatter of the next).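

In this assay, the direct exchange on this aromatic carbon gives no readable change (a 1.2-fold lower number from compound 3 to compound 4 (0.09 log units; within the scatter)), although the entering methoxy brings one hydrogen-bond acceptor that fluoro lacks. Within the data shown here, on the oxygen, methyl also reads the same as the larger groups, both against isobutyl (a 1.1-fold higher number from compound 2 to compound 4 (0.06 log units; within the scatter)) and against isopropylcarbonyl (a 1.6-fold lower number from compound 1 to compound 4 (0.20 log units; within the scatter)), so all four groups tested at this place now lie within the scatter of one another, with no compound going against that. No evidence is available that bears on this result.

From the compounds shown here alone, whether an amine or a carboxylic acid on this aromatic carbon, or a longer chain on its oxygen, would move the number beyond the scatter remains open. Going by these compounds, whether changes elsewhere on the shared core would do so also remains open.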